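Anilino replaces butylamino on the isopropyl core

The source may report more compounds than this note shows. Statements on the series, on what has been measured and on what is new or still open speak of the compounds shown alone.

The series is read in a functional assay on G-361 cells (Homo sapiens) for cytotoxicity, read by sulforhodamine B assay; on this read-out lower numbers stand for stronger inhibition of growth and higher numbers for weaker inhibition of growth. Compound 2 `CCCCNc1nc(CC)nc2c1cnn2-c1ccccc1` gives 32000 nM. Compound 3 `CCCCNc1nc(C(C)C)nc2c1cnn2-c1ccccc1` gives only a limit, > 100000 nM. Compound 1 `Cc1nc(Nc2ccccc2)c2cnn(-c3ccccc3)c2n1` likewise reaches only a limit, > 100000 nM. Within the data shown here, the one measured step, an at least 3.1-fold higher number from compound 2 to compound 3 (0.49 log units; beyond the scatter), shows the added methyl on the saturated chain carbon weakening growth inhibition. Compound 4 `CC(C)c1nc(Nc2ccccc2)c2cnn(-c3ccccc3)c2n1` differs from compound 3 by phenyl in place of butyl on a nitrogen on an aromatic ring. Among the measured compounds shown here, no measured step covers this exchange. Compound 1, which carries the same anilino group, stands at the limit of > 100000 nM in this assay, at which 2 of the 3 values shown sit. Compound 3 stands there too. Compound 4 is therefore expected to remain at that limit, with the step of a number no higher from compound 3 to compound 4 (the limit leaves the size open) being none beyond the scatter. The estimate for compound 4 is 100000 nM, within 50000 nM to 400000 nM.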

Compound 4, concentration for total growth inhibition: > 100000 nM
Compound 4: a limit, no number; the forecaster's own chance of this, stated with the estimate: 80%; the middle value lies on the limit itself.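

The steps from compound 3 and from compound 1 to compound 4 cannot be read, as all three compounds give only limits. Going by these compounds, whether phenyl in place of butyl, or isopropyl in place of methyl, alters growth inhibition stays open.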